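The source may report more compounds than this note shows. Statements on the series, on what has been measured and on what is new or still open speak of the compounds shown alone.

In a functional assay on MDA-MB-231 cells (Homo sapiens) for inhibition, read by MTT assay, with a stated time of 48 h (on this read-out higher numbers stand for weaker inhibition and lower numbers for stronger inhibition), three compounds have been measured so far:

compound 1 `COc1ccc(-c2nc3cc(/C=C4\SC(=O)NC4=O)ccc3[nH]2)cc1OC`, 13600 nM
compound 2 `COc1cc(-c2nc3cc(/C=C4\SC(=O)NC4=O)ccc3[nH]2)ccc1OCC(C)C`, 7780 nM
compound 3 `COc1ccc(-c2nc3cc(/C=C4\SC(=O)N(Cc5cc(OC)c(OC)c(OC)c5)C4=O)ccc3[nH]2)cc1OC`, 29100 nM

Compound 1 and compound 2 differ in one place only: isopropyl in place of hydrogen on a saturated chain carbon bound to an oxygen on an aromatic ring. This change brought a 1.7-fold lower number from compound 1 to compound 2 (0.24 log units; within the scatter), a step too small to count as a real difference between the two. Compound 3 shares its core with compound 1 but differs from it in more than one place, so the difference between the two cores is not broken down here. In this assay compound 3 gives the highest number of the three, and both compound 1 and compound 2 give lower numbers by more than the usual scatter.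

Compound 4 `COc1cc(-c2nc3cc(/C=C4\SC(=O)N(Cc5cc(OC)c(OC)c(OC)c5)C4=O)ccc3[nH]2)ccc1OCC(C)C` has not yet been measured. It is made from compound 3 by the same change that turned compound 1 into compound 2, namely (isopropyl in place of hydrogen on a saturated chain carbon bound to an oxygen on an aromatic ring), at the same place. Among the compounds with values here, the only guide to what this change does is the one earlier step, a 1.7-fold lower number from compound 1 to compound 2 (0.24 log units; within the scatter), which lay within the scatter. For compound 4 the expected step is therefore a 1.7-fold lower number from compound 3 to compound 4 (0.23 log units; within the scatter), again a small one. Because compound 3 gives 29100 nM, compound 4 is expected to give 17000 nM, with 8000 nM and 36000 nM as the ends of the expected range.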

Compound 4, half-maximal inhibitory concentration: 4370 nM
The estimate for compound 4 lay 3.9-fold (0.59 log units) above the measured number; the measured number lies below the stated range.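

In this assay, replacing the methoxy with isobutoxy on the core of compound 3 gave a 6.7-fold lower number from compound 3 to compound 4 (0.82 log units; beyond the scatter), a step large enough to count as a real difference on this core. The same replacement did not bring a step of the same size on both cores, so the result from one core cannot simply be copied to the other: the same change on two cores in this assay, a 1.7-fold lower number (0.24 log units; within the scatter) from compound 1 to compound 2 and a 6.7-fold lower number (0.82 log units; beyond the scatter) from compound 3 to compound 4, 3.8-fold (0.58 log units) apart, beyond the scatter of two such steps. This shows that the size of the step depends on the core in this pair of examples, but it does not show why, and two cores are too few to give a general rule for the series or to say which part of the core matters.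

The compounds shown carry only methoxy or isobutoxy at this place, so it remains open what a longer chain, such as hexyloxy, or a chain ending in an amine or a carboxylic acid would do there. Going by these compounds, it also remains open whether a third core would give a step closer to the small one or the large one, and that is the comparison needed to judge how far this change can be relied on across the series.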